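The compounds below may be only part of what the source reports. "The series", "measured", "known", "first", "only" and "open" are said of these compounds alone.

Measured so far in a physicochemical assay for lipophilicity, measured as octanol-water partition; on this read-out higher numbers stand for higher lipophilicity and lower numbers for lower lipophilicity:
- compound 1, `O=C(NNc1ccnc2cc(Cl)ccc12)c1ccccc1/N=C/c1ccc(Cl)c(Cl)c1`: 6.22
- compound 2, `N#Cc1ccc(/C=N/c2ccccc2C(=O)NNc2ccnc3cc(Cl)ccc23)cc1`: 4.83

Compound 1 stands highest of the two numbers; its nearest neighbour is compound 2, the step being a number 1.39 log units lower from compound 1 to compound 2 (beyond the scatter), which comes from putting 4-cyanophenyl in place of 3,4-dichlorophenyl on a carbon with a double bond to nitrogen.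

Compound 3, `O=C(NNc1ccnc2cc(Cl)ccc12)c1ccccc1/N=C/c1cc2ccccc2nc1Cl`, is not yet measured. It differs from compound 1 as follows: 2-chloroquinolin-3-yl in place of 3,4-dichlorophenyl on a carbon with a double bond to nitrogen

Going by the values given here, the only measured step that bears on this one is the step from compound 1 to compound 2 (a number 1.39 log units lower from compound 1 to compound 2 (beyond the scatter)), and it changes the same aryl group on the same carbon with a double bond to nitrogen. That step was large. The change to compound 3 keeps one chlorine and adds a fused ring with a nitrogen, so a smaller downward step is expected, roughly a number 0.62 log units lower from compound 1 to compound 3 (beyond the scatter). For compound 3 the expected reading in this assay is therefore 5.6, with a range from 5 to 6.2.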

Compound 3, partition coefficient: 6
For compound 3 the middle estimate is 0.40 log units below the measured one; the range from low to high includes it.
By their numbers in this assay, from the lowest: compound 2; then compounds 3 and 1 (each within the scatter of the next).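

In this assay, 2-chloroquinolin-3-yl and 3,4-dichlorophenyl cannot be told apart on a carbon with a double bond to nitrogen (a number 0.22 log units lower from compound 1 to compound 3 (within the scatter)), so exchanging the aryl group here need not shift the read-out, even when the new group carries a second ring and a ring nitrogen. The same group also stands clearly apart from 4-cyanophenyl (a number 1.17 log units higher from compound 2 to compound 3 (beyond the scatter)), which leaves compound 2 as the only one of the three with a markedly different reading. Nothing measured on these compounds accounts for either step.

Still open is whether the chlorine of 2-chloroquinolin-3-yl contributes to the reading, as no unchlorinated quinolin-3-yl counterpart is among the compounds shown. Also open, going by these compounds, is how this assay responds to a carboxylic acid or an aliphatic amine on the aryl group at this carbon.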